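The source may hold more compounds than are shown below. What is called first, only, known or untested is meant among the compounds shown, and "the series" means these compounds.

Of the compounds shown here, three of a shared core have been measured in a functional assay on DU-145 cells (Homo sapiens) for cytotoxicity, read by MTT assay, with a stated time of 72 h; a higher number here means a weaker inhibitor, a lower number a stronger inhibitor. Compound 3 `C#CCn1cc(C(=O)NC(CC(=O)Nc2ccccn2)c2ccccc2)c(=O)c2cc(F)c(Cl)nc21` gives 2100 nM in this assay, the lowest of the two numbers read; the nearest is compound 1 `C#CCn1cc(C(=O)NC(CC(=O)NC2CCCCC2)c2ccccc2)c(=O)c2cc(F)c(Cl)nc21`, which in this assay gives 8030 nM. Compound 2 `C#CCn1cc(C(=O)NC(CC(=O)NC2CCCC2)c2ccccc2)c(=O)c2ccc(Cl)nc21` reaches only the limit of this assay, > 10000 nM, and no number. Going by the values given here, one measured step bears directly on the question at hand: replacing cyclohexyl with pyridin-2-yl on the amide-type nitrogen gave a 3.8-fold lower number from compound 1 to compound 3 (0.58 log units; beyond the scatter).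

Compound 4 `C#CCn1cc(C(=O)NC(CC(=O)NC2CCCC2)c2ccccc2)c(=O)c2cc(F)c(Cl)nc21` differs from compound 3 in one place: cyclopentyl in place of pyridin-2-yl on an amide-type nitrogen. This is, in effect, the reverse of the measured step, with a five-membered ring entering where a six-membered one had left before. Among the compounds with values here, the only measured example of the reverse direction was a modest change beyond the scatter, so a move back toward the number of compound 1, or somewhat past it, is the expectation here, because a 3.8-fold lower number from compound 1 to compound 3 (0.58 log units; beyond the scatter) is the sole guide. For compound 4 the expected step is therefore a 4.3-fold higher number from compound 3 to compound 4 (0.63 log units; beyond the scatter), a higher number. Compound 4 is thus estimated at 9000 nM in this assay, with a range of 4000 nM to 25000 nM.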

Compound 4, half-maximal inhibitory concentration: > 10000 nM
Compound 4: no number, only a limit; the forecaster's own chance of this, stated with the estimate: 40%; middle value at least 1.1-fold (0.04 log units) from the limit.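

On the amide-type nitrogen in this assay, the change to cyclopentyl gives an at least 4.7-fold higher number from compound 3 to compound 4 (0.67 log units; beyond the scatter), so pyridin-2-yl now has a lower number than either of the two carbon-only rings set against it, not just cyclohexyl. The comparison of those two rings gives an at least 1.2-fold higher number from compound 1 to compound 4 (0.09 log units; that floor lies within the scatter); that floor lies within the scatter, so the data do not separate cyclopentyl from cyclohexyl at this position. The effect of fluoro in place of hydrogen on the aromatic carbon cannot be read, because compound 2 and compound 4 each stop at a limit rather than a number: the limit of > 10000 nM in this assay, at which 2 of the 4 values shown sit.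

The compounds shown leave open whether a plain phenyl on the same nitrogen would read like pyridin-2-yl or like the carbon-only rings, which would show whether the aromatic ring or its nitrogen goes with the lower number. They also leave open whether pyridin-3-yl or pyridin-4-yl would keep the number of compound 3, and how a piperidin-4-yl ring, with its nitrogen in a saturated ring, would compare.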